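The source may report more compounds than this note shows. Statements on the series, on what has been measured and on what is new or still open speak of the compounds shown alone.

Series notes. Compound 2 `COc1ccc(CNc2nc(SC)nc3ncccc23)cc1` and compound 1 `CSc1ccc(CNc2nc(SC)nc3ncccc23)cc1` share one core. In an ADME assay on 184B5 cells (Homo sapiens) for cytotoxicity, read by MTT assay, with a stated time of 72 h (a higher number here means a weaker inhibitor of growth, a lower number a stronger inhibitor of growth), compound 2 gives 69800 nM and compound 1 gives 1140 nM; the step of a 61-fold lower number from compound 2 to compound 1 (1.79 log units; beyond the scatter) follows the change (methylsulfanyl in place of methoxy on an aromatic carbon). Compound 3 `COc1ccc(CNc2nc(SC)nc3ccccc23)cc1` carries the methoxy group of compound 2 on another core; the difference between the two cores is not broken down here. In this assay compound 3 is reported only at the limit of > 100000 nM in this assay, at which 1 of the 3 values shown sits, a limit of the assay and not a number, so compound 3 stands at > 100000 nM. Compound 4 `CSc1ccc(CNc2nc(SC)nc3ccccc23)cc1` is not yet measured and differs from compound 3 by methylsulfanyl in place of methoxy on an aromatic carbon, the same change, at the same place, as from compound 2 to compound 1. Compound 4 is expected to take a step of about an at least 20-fold lower number from compound 3 to compound 4 (1.30 log units; beyond the scatter), which rests on the earlier drop a 61-fold lower number from compound 2 to compound 1 (1.79 log units; beyond the scatter). The starting point is uncertain since compound 3 is known only as a limit > 100000 nM. For compound 4 the estimate in this assay is 5000 nM, expected to lie between 1000 nM and 50000 nM.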

Compound 4, concentration for total growth inhibition: > 100000 nM
Compound 4 was reported as a limit; the forecaster's own chance of this, stated with the estimate: 20%; middle value at least 20-fold (1.30 log units) from the limit.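

In this assay compound 3 and compound 4 both stand only as limits of the assay, so no step between them can be read: the limit of > 100000 nM in this assay, at which 2 of the 4 values shown sit.

The compounds shown leave open whether methylsulfanyl in place of methoxy shifts the number on the core of compound 3, as it does on the core of compound 1.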